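The source may report more compounds than this note shows. Statements on the series, on what has been measured and on what is new or still open speak of the compounds shown alone.

Values in a functional assay on MDA-MB-435 cells (Homo sapiens) for cytotoxicity, read by MTT assay, with a stated time of 72 h; on this read-out lower numbers stand for stronger inhibition and higher numbers for weaker inhibition:
- compound 1 `CC(C)(C)OC(=O)N1CCN(c2c(C(=O)NCc3ccc(F)cc3)nc(Br)c3cccnc23)CC1`: 10000 nM
- compound 2 `N[C@H]1CC[C@H](Nc2c(C(=O)NCc3ccc(F)cc3)nc(Br)c3cccnc23)CC1`: 6000 nM
- compound 3 `NCCNc1c(C(=O)NCc2ccc(F)cc2)nc(Br)c2cccnc12`: 12000 nM

Compound 3 lies within the scatter of both compound 1 and compound 2, so it has no distinct place among the three. The next structure is compound 4 `O=C(NCc1ccc(F)cc1)c1nc(Br)c2cccnc2c1N1CCNCC1`, and the change is piperazin-1-yl in place of (2-aminoethyl)amino on an aromatic carbon, para to the bromo group.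

Going by the values given here, only one measured step bears on this directly: a 2.0-fold higher number from compound 2 to compound 3 (0.30 log units; within the scatter). It exchanges one amine-bearing substituent for another at the same place and stays within the scatter. Compound 1 also carries a piperazine ring on that carbon, with a substituent on its second nitrogen, and gives 10000 nM. Among the compounds with values here, no measured step shows how the free piperazine behaves, so this support is limited.

No step beyond the scatter is expected in this assay, and the estimated step is a 1.2-fold lower number from compound 3 to compound 4 (0.08 log units; within the scatter). Compound 4 is expected at 10000 nM, with an estimated range from 4000 nM to 25000 nM.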

Compound 4, half-maximal inhibitory concentration: 8000 nM
Estimate against measurement, compound 4: 1.3-fold (0.10 log units) above; the measured number falls inside the stated range.
By their numbers in this assay, from the lowest: compounds 2, 4, 1 and 3 (each within the scatter of the next).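

In this assay, piperazin-1-yl on this aromatic carbon, para to a bromo group, gives a 1.5-fold lower number from compound 3 to compound 4 (0.18 log units; within the scatter) against the (2-aminoethyl)amino group and a 1.3-fold higher number from compound 2 to compound 4 (0.12 log units; within the scatter) against the (4-aminocyclohexyl)amino group, so the ring and both open amines are not told apart here. Going by these compounds alone, compound 4 also isolates the tert-butoxycarbonyl group on the ring nitrogen for the first time: its replacement by hydrogen gives a 1.3-fold lower number from compound 1 to compound 4 (0.10 log units; within the scatter) and leaves that nitrogen's substituent without a measurable effect in this set. No supporting measurement accounts for this flat response.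

From the compounds shown here alone, whether a morpholin-4-yl ring or a longer aminoalkyl chain on this carbon moves the number beyond the scatter remains open. Going by these compounds, all four compounds keep the bromo group and the 4-fluorobenzyl amide, so the role of those parts also stays unknown.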